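Formylthiophene attachment change on the shared core

A few compounds are considered here, and "the series" means these few. Any claim that something is new, unique, unknown or untested is made for them only; others in the source may bear on it.

In a functional assay on MV4-11 cells (Homo sapiens) for inhibition, read by resazurin assay, with a stated time of 72 h (on this read-out lower numbers stand for stronger inhibition of growth and higher numbers for weaker inhibition of growth), compound 1 `O=C1NCCC12CCN(c1c(Cl)cncc1-c1ccco1)CC2` gives 940 nM, compound 2 `Cc1ccsc1-c1cncc(Cl)c1N1CCC2(CCNC2=O)CC1` gives 910 nM and compound 3 `O=Cc1ccc(-c2cncc(Cl)c2N2CCC3(CCNC3=O)CC2)s1` gives 750 nM, so compound 3 stands within the scatter of both others. Compound 4 `O=Cc1cc(-c2cncc(Cl)c2N2CCC3(CCNC3=O)CC2)cs1` has the same atoms as compound 3, joined differently: 5-formylthiophen-3-yl in place of 5-formylthiophen-2-yl on an aromatic carbon. The change is 5-formylthiophen-3-yl in place of 5-formylthiophen-2-yl on an aromatic carbon. The closest evidence is the group swaps at this place: a 1.0-fold lower number from compound 1 to compound 2 (0.01 log units; within the scatter), a 1.3-fold lower number from compound 1 to compound 3 (0.10 log units; within the scatter) and a 1.2-fold lower number from compound 2 to compound 3 (0.08 log units; within the scatter), all within the scatter. None of them tests a change of attachment alone, so the inference is indirect. In this assay no step beyond the scatter is expected. The expected step is a 1.1-fold higher number from compound 3 to compound 4 (0.03 log units; within the scatter). For compound 4 the estimated value is 800 nM, with a range of 400 nM to 1600 nM.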

Compound 4, concentration for 50% growth inhibition: 730 nM
Estimate against measurement, compound 4: 1.1-fold (0.04 log units) above; measured number inside the range.
By their numbers in this assay, from the lowest: compounds 4, 3, 2 and 1 (each within the scatter of the next).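

Compound 4 gives the one direct test of a change of attachment alone at this position, and in this assay the swap of 5-formylthiophen-2-yl for 5-formylthiophen-3-yl stays within the scatter (a 1.0-fold lower number from compound 3 to compound 4 (0.01 log units; within the scatter)). The other two steps ending at compound 4 also stay within the scatter (a 1.2-fold lower number from compound 2 to compound 4 (0.10 log units; within the scatter); a 1.3-fold lower number from compound 1 to compound 4 (0.11 log units; within the scatter)), so the four groups shown here cannot be told apart. Nothing available here accounts for this flat reading. Open, on these data alone, is whether an aminomethyl or carboxylic acid group on the thiophene would give a step beyond the scatter.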